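This account rests on a few compounds, and the source may have more. Where it says the series, first, only, none or still open, it means among the compounds named here.

The three compounds measured so far, all in a functional assay on K562 cells (Homo sapiens) for antiproliferative activity, read by MTT assay, with a stated time of 72 h; on this read-out lower numbers stand for stronger inhibition and higher numbers for weaker inhibition:

Compound 1, `COc1cc(C(=O)c2sc3ccccc3c2-c2ccc(Cl)cc2)cc(OC)c1OC`, gives 4200 nM.
Compound 2, `COc1cc(C(=O)c2sc3ccccc3c2-c2ccc(C)cc2)cc(OC)c1OC`, gives 3500 nM.
Compound 3, `COc1cc(C(=O)c2sc3ccccc3c2Nc2ccc(Cl)cc2)cc(OC)c1OC`, gives 1100 nM.

Compound 1 and compound 2 share a core and differ by methyl in place of chloro on an aromatic carbon; that exchange made a 1.2-fold lower number from compound 1 to compound 2 (0.08 log units; within the scatter), so the two numbers cannot be told apart. Compound 3 carries a different core: against compound 1 the difference is (4-chlorophenyl)amino in place of 4-chlorophenyl on an aromatic carbon, and it brought a 3.8-fold lower number from compound 1 to compound 3 (0.58 log units; beyond the scatter). Against compound 2, whose core is that of compound 1, the move to compound 3 gave a 3.2-fold lower number from compound 2 to compound 3 (0.50 log units; beyond the scatter). Compound 3 therefore stands with the lowest number of the three, and both of its steps to the others lie beyond the scatter.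

Compound 4, `COc1cc(C(=O)c2sc3ccccc3c2Nc2ccc(C)cc2)cc(OC)c1OC`, has not yet been measured. It stands to compound 3 as compound 2 stands to compound 1: the difference is methyl in place of chloro on an aromatic carbon, at the same place as in the earlier pair, on an aromatic carbon of a six-membered aromatic ring of carbon only, para to a large group; only the core that bears the ring differs, as described above. Because the earlier exchange made a 1.2-fold lower number from compound 1 to compound 2 (0.08 log units; within the scatter), compound 4 is expected to sit close to compound 3, with an estimated step of a 1.2-fold lower number from compound 3 to compound 4 (0.06 log units; within the scatter). The estimate for compound 4 in this assay is 950 nM, expected to fall between 450 nM and 2000 nM.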

Compound 4, half-maximal inhibitory concentration: 1600 nM
The estimate for compound 4 lay 1.7-fold (0.23 log units) below the measured number; the range from low to high includes it.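

In this assay, methyl in place of chloro on the core of compound 3 gave a 1.5-fold higher number from compound 3 to compound 4 (0.16 log units; within the scatter), and the same exchange on the core of compound 1 does not read differently: the same change on two cores in this assay, a 1.2-fold lower number (0.08 log units; within the scatter) from compound 1 to compound 2 and a 1.5-fold higher number (0.16 log units; within the scatter) from compound 3 to compound 4, 1.7-fold (0.24 log units) apart, within the scatter of two such steps On both cores the exchange therefore left the number within the scatter, while the difference between the cores remained visible with methyl in place, as a 2.2-fold lower number from compound 2 to compound 4 (0.34 log units; beyond the scatter), and across the pair that also differs in chloro and methyl, as a 2.6-fold lower number from compound 1 to compound 4 (0.42 log units; beyond the scatter). Within the data shown here, this shows that a small step carried over from one core to the other for this single exchange, but it does not show that the two steps are identical, and it rests on only one pair of compounds on each core, so it cannot be extended to other groups.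

The compounds shown hold only chloro and methyl at this place on the aromatic ring, which leaves open whether a methoxy, a trifluoromethyl or a dimethylamino group would also carry across the two cores with so small a step. They also leave open how the number would respond if an ether oxygen or a methylated amine took the place of the amino link in compound 3 and compound 4.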